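Working notes: from compound 1 to compound 3

A few compounds are considered here, and "the series" means these few. Any claim that something is new, unique, unknown or untested is made for them only; others in the source may bear on it.

Compound 1 `COc1cc(OC)c(/C=C/S(=O)(=O)Cc2cnc(Cl)cn2)c(OC)c1`: > 10000 nM
Compound 2 `COc1cc(OC)c(/C=C/S(=O)(=O)Nc2cnc(Cl)cn2)c(OC)c1`: > 10000 nM

Both entries come from a functional assay on HCT-116 cells (Homo sapiens) for antiproliferative activity, read by MTT assay, with a stated time of 72 h (a lower number here means a stronger inhibitor of growth, a higher number a weaker inhibitor of growth), and each is a limit, not a number. Compound 1 therefore stands only at its limit of > 10000 nM. The same ceiling holds for the pair: the limit of > 10000 nM in this assay, at which 2 of the 2 values shown sit. Among the measured compounds shown here, the one measured step is a step that the two limits leave unreadable from compound 1 to compound 2, and it concerns a different change from the one ahead.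

Compound 3 `COc1cc(OC)c(/C=C/S(=O)(=O)Cc2nc(Cl)ncc2OC)c(OC)c1` differs from compound 1 as follows: 2-chloro-5-methoxypyrimidin-4-yl in place of 5-chloropyrazin-2-yl on a saturated chain carbon bound to a sulfonyl sulfur. That is, 2-chloro-5-methoxypyrimidin-4-yl in place of 5-chloropyrazin-2-yl on a saturated chain carbon bound to a sulfonyl sulfur. For the measured compounds named here, no measured step gives a size for this change, and none supports a direction. The expectation rests on compound 1, whose limit of > 10000 nM is the only anchor. The expected step is a step that the limit leaves unreadable from compound 1 to compound 3, with no change beyond the scatter anticipated. For compound 3 the estimated value in this assay is 12000 nM, with an expected range of 3000 nM to 30000 nM.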

Compound 3, concentration for 50% growth inhibition: > 10000 nM
Compound 3 gave a limit, no number (the forecaster's own chance of this, stated with the estimate: 75%); the middle value lies beyond the limit too.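

No new step can be read among compound 1, compound 2 and compound 3, because each value is a limit and not a number: the limit of > 10000 nM in this assay, at which 3 of the 3 values shown sit. The compounds shown leave open whether either change alters growth inhibition at all.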